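Notes on the aryl-imine urea series: expected dose for compound 4

A few compounds are considered here, and "the series" means these few. Any claim that something is new, unique, unknown or untested is made for them only; others in the source may bear on it.

Measured so far:
compound 1, `O=C(/N=C/c1ccccc1)Nc1ccc2c(c1)C(=O)C(=O)N2CN1CCCCC1`, 300 mg/kg
compound 2, `O=C(/N=C/c1ccc(Cl)cc1)Nc1ccc2c(c1)C(=O)C(=O)N2CN1CCCCC1`, 300 mg/kg
compound 3, `O=C(/N=C/c1ccc([N+](=O)[O-])cc1)Nc1ccc2c(c1)C(=O)C(=O)N2CN1CCCCC1`, 300 mg/kg

All three readings come from a functional assay on the whole organism (strain Swiss albino) with Mus musculus as the target, with a stated time of 0.5 h; on this read-out higher numbers stand for an effect only at larger amounts of compound and lower numbers for an effect already at smaller amounts. Compound 3 stands level with compound 1 and compound 2 at the digits given; the step of no change at the digits printed from compound 1 to compound 3 (within the scatter) and the step of no change at the digits printed from compound 2 to compound 3 (within the scatter) both stay within the scatter, as does no change at the digits printed from compound 1 to compound 2 (within the scatter). The ring on the imine side thus carried hydrogen, chloro or nitro without any visible shift in the dose.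

Compound 4, `COc1ccc(/C=N/C(=O)Nc2ccc3c(c2)C(=O)C(=O)N3CN2CCCCC2)cc1`, is next. Its difference from compound 3 is methoxy in place of nitro on an aromatic carbon; cut one bond further out, the 4-nitrophenyl becomes 4-methoxyphenyl. Among the compounds with values here, no measured step introduces methoxy, so the closest guides are the steps that altered the same aromatic carbon: no change at the digits printed from compound 1 to compound 3 (within the scatter) and no change at the digits printed from compound 2 to compound 3 (within the scatter), both flat. On that evidence the step of no change at the digits printed from compound 3 to compound 4 (within the scatter) is expected to stay within the scatter, with no direction favoured. Compound 4 is therefore estimated at 300 mg/kg, in the range 150 mg/kg to 600 mg/kg in this assay.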

Compound 4, minimum effective dose: 300 mg/kg
Compound 4: middle estimate and measured number agree at the digits printed, within the range that was stated.
By their numbers in this assay, from the lowest: compounds 1, 2, 3 and 4 (each within the scatter of the next).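

Exchanging the 4-nitrophenyl for 4-methoxyphenyl puts a group of one carbon and one oxygen where one nitrogen and two oxygens stood, and in this assay this gives no change at the digits printed from compound 3 to compound 4 (within the scatter), so the flat reading on this aromatic carbon, para to a large group, now extends to methoxy. Within the data shown here, the other two comparisons agree, with no change at the digits printed from compound 2 to compound 4 (within the scatter) for methoxy in place of chloro and no change at the digits printed from compound 1 to compound 4 (within the scatter) for methoxy in place of hydrogen, leaving hydrogen, chloro, nitro and methoxy all level at this place, with no compound in the set going against that reading. No measured information is available to explain why the dose stays level across these four groups.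

Open, as far as these compounds go, is whether an amine or a carboxylic acid on this same aromatic carbon, or a longer chain such as butoxy in place of methoxy, would also leave the dose level. From the compounds shown here alone, all four compounds share one core, and what any change to that core does to the dose remains open.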